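The source may report more compounds than this note shows. Statements on the series, on what has been measured and on what is new or still open speak of the compounds shown alone.

Compound 3 `Oc1cccc(-c2cc(-c3ccc(Cl)cc3)nc(-c3ccsc3)c2)c1` is one of three close relatives in this set, alongside compound 1 `Oc1cccc(-c2cc(-c3ccncc3)nc(-c3ccccc3Cl)c2)c1` and compound 2 `Oc1cccc(-c2cc(-c3ccco3)nc(-c3ccccc3Cl)c2)c1`. In a functional assay on HCT-15 cells (Homo sapiens) for cytotoxicity, read by CCK-8 assay and cell counting, with a stated time of 2 days (on this read-out higher numbers stand for weaker inhibition and lower numbers for stronger inhibition), compound 1 gives "not determined" (no result reported), so no number is available for it. In this assay compound 2 gives 2230 nM, while compound 3 gives 8850 nM, the highest of the two numbers and a gap to compound 2 that lies beyond the scatter. Compound 4 `Oc1cccc(-c2cc(-c3ccsc3)nc(-c3ccccc3Cl)c2)c1` has not yet been measured; it differs from compound 3 in a single place: 2-chlorophenyl in place of 4-chlorophenyl on an aromatic carbon. Among the compounds with values here, compound 2, which also carries a 2-chlorophenyl group, offers the only guide, and on that basis a step from compound 3 to compound 4 of moderate size toward a lower number is expected, a 2.5-fold lower number from compound 3 to compound 4 (0.40 log units; beyond the scatter). Compound 4 is therefore estimated at 3500 nM, within a range from 1200 nM to 10000 nM.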

Compound 4, half-maximal inhibitory concentration: 2500 nM
For compound 4 the middle estimate is 1.4-fold (0.15 log units) above the measured one; low and high end bracket the measured number.
By their numbers in this assay, from the lowest: compounds 2 and 4 (each within the scatter of the next); then compound 3.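

In this assay, 2-chlorophenyl in place of 4-chlorophenyl, next to the ring nitrogen, gives a 3.5-fold lower number from compound 3 to compound 4 (0.55 log units; beyond the scatter), so with the same atoms, where the chlorine sits on this phenyl ring is enough to separate the two compounds. With 2-chlorophenyl held fixed, thiophen-3-yl in place of furan-2-yl gives a 1.1-fold higher number from compound 2 to compound 4 (0.05 log units; within the scatter), so that exchange does not separate them. Nothing at hand accounts for either step. Still open, as far as these compounds go, is how an amine or a carboxylic acid in place of the chlorine would read, and whether the step between the two chlorophenyl groups recurs with furan-2-yl on the shared core.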